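The source may hold more compounds than are shown below. What is called first, only, known or untested is meant among the compounds shown, and "the series" means these compounds.

Compound 1, `O=C(c1ccc(Cl)nc1)N1CCC(NS(=O)(=O)c2cc(S(=O)(=O)c3ccccc3)ccc2C(F)(F)F)CC1`, gives 0.15 h in an in vitro ADME assay on microsomes from liver (Rattus norvegicus) for metabolic stability, tested at 1 uM; a higher number here means that the compound lasts longer, a lower number that the compound disappears faster. Compound 2, `O=C(O)c1cccc(S(=O)(=O)N2CCC(NS(=O)(=O)c3cc(S(=O)(=O)c4ccccc4)ccc3C(F)(F)F)CC2)c1`, gives 0.383 h. Compound 3, `O=C(C1CCNCC1)N1CCC(NS(=O)(=O)c2cc(S(=O)(=O)c3ccccc3)ccc2C(F)(F)F)CC1`, gives only a limit of this assay, > 0.5 h.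

Among the two plain numbers, compound 1 stands lowest; its nearest neighbour is compound 2, reached by a 2.6-fold higher number from compound 1 to compound 2 (0.41 log units; beyond the scatter). Compound 4, `O=C([C@@H]1CCNC1)N1CCC(NS(=O)(=O)c2cc(S(=O)(=O)c3ccccc3)ccc2C(F)(F)F)CC1`, differs from compound 1 by pyrrolidin-3-yl in place of 6-chloropyridin-3-yl on a carbonyl carbon. For the measured compounds named here, the step that bears on this change is the one to compound 3, where a saturated nitrogen ring also replaces 6-chloropyridin-3-yl on the carbonyl carbon: an at least 3.3-fold higher number from compound 1 to compound 3 (0.52 log units; beyond the scatter). A rise of similar, modest size is therefore expected for compound 4, a 3.3-fold higher number from compound 1 to compound 4 (0.52 log units; beyond the scatter). The estimate for compound 4 in this assay is 0.5 h, within a range of 0.3 h to 0.9 h.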

Compound 4, half-life: > 0.5 h
Compound 4 was reported as a limit; the forecaster's own chance of this, stated with the estimate: 50%; the middle value sits exactly at the limit.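

In this assay compound 4 gives only a limit, > 0.5 h. Pyrrolidin-3-yl in place of 6-chloropyridin-3-yl on the carbonyl carbon gives an at least 3.3-fold higher number from compound 1 to compound 4 (0.52 log units; beyond the scatter), so the rise is not confined to piperidin-4-yl but also comes with a five-membered non-aromatic ring. Against the (3-carboxyphenyl)sulfonyl group, the change gives an at least 1.3-fold higher number from compound 2 to compound 4 (0.11 log units; that floor lies within the scatter).

On these data alone, the step between the two non-aromatic rings cannot be read because it rests on two limits: the limit of > 0.5 h in this assay, at which 2 of the 4 values shown sit. Whether a cyclopentyl ring or an open aminoalkyl chain on the carbonyl carbon would bring the same rise remains open.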